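The source may report more compounds than this note shows. Statements on the series, on what has been measured and on what is new or still open speak of the compounds shown alone.

Measured compounds in an assay for binding affinity to Alpha-1B adrenergic receptor (Homo sapiens), read by radioligand binding; a higher number here means a weaker inhibitor, a lower number a stronger inhibitor:
- compound 1 `COc1ccc(S(C)(=O)=O)c(NCC2=NCCN2)c1` gives 4570 nM
- compound 2 `CSc1ccc(C)cc1NCC1=NCCN1` gives 123 nM
- compound 3 `CS(=O)(=O)c1ccc(F)cc1NCC1=NCCN1` gives 1320 nM

Compound 3 holds the second highest number of the three. Its nearest neighbour is compound 1, whose number is higher, and the furthest is compound 2, whose number is lower by a wider margin.

The unmeasured compound 4 `Cc1ccc(S(C)(=O)=O)c(NCC2=NCCN2)c1` arises from compound 3 by a single change: methyl in place of fluoro on an aromatic carbon. Among the compounds with values here, only one measured step touches the same position on the ring, namely a 3.5-fold lower number from compound 1 to compound 3 (0.54 log units; beyond the scatter), which swapped methoxy for fluoro. That step was modest and moved the number downward. Within the data shown here, compound 2 also carries a methyl on its ring, but it differs from compound 3 in a second place as well, so no single step connects them; all that can be said is that compound 2 shows the lowest number of the three, with compound 3 well above it.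

Taken together, the one bearing step and the favourable number of the methyl-bearing compound 2 suggest that compound 4 is expected to show a modest downward step, a 1.7-fold lower number from compound 3 to compound 4 (0.22 log units; within the scatter), in this assay. The estimate for compound 4 is therefore 800 nM, with a range from 300 nM to 2500 nM.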

Compound 4, inhibition constant: 3470 nM
Compound 4: the middle estimate sits 4.3-fold (0.64 log units) below what was measured; the measured number lies above the stated range.
By their numbers in this assay, from the lowest: compound 2; then compound 3; then compounds 4 and 1 (each within the scatter of the next).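

In this assay, the ring carbon para to the methylsulfonyl group proves sensitive to the change from fluoro to methyl: a 2.6-fold higher number from compound 3 to compound 4 (0.42 log units; beyond the scatter) is beyond the scatter and removes the lower number that fluoro had given, so that, of the three groups shown there, fluoro alone stands apart. Methyl and methoxy cannot be separated at this position, since a 1.3-fold lower number from compound 1 to compound 4 (0.12 log units; within the scatter) lies within the scatter. The methyl that compound 2 carries does not by itself secure a low number, as a 28-fold higher number from compound 2 to compound 4 (1.45 log units; beyond the scatter) is a large step and ties that low number, in this pair, to methylsulfanyl rather than methylsulfonyl. Nothing available gives a measured reason for any of these differences.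

With methylsulfanyl in the place of methylsulfonyl, only methyl is shown on this ring carbon, so it remains open whether fluoro would lower the number there as well. From the compounds shown here alone, it is also open how chloro, a nitrile or an amine at this position would compare with fluoro.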